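A few compounds are considered here, and "the series" means these few. Any claim that something is new, unique, unknown or untested is made for them only; others in the source may bear on it.

The measured compounds in a functional assay on PC-3 cells (Homo sapiens) for cytotoxicity, read by sulforhodamine B assay, with a stated time of 72 h (on this read-out higher numbers stand for weaker inhibition of growth and lower numbers for stronger inhibition of growth), are: compound 1 `O=C(Nc1ccccc1C(F)(F)F)C1CCc2ccccc2N1` with 53300 nM; compound 2 `O=C(Nc1ccccc1C(F)(F)F)C1CCc2ccccc2N1C(=O)c1ccccc1` with 5560 nM; compound 3 `O=C(Nc1ccccc1O)C1CCc2ccccc2N1C(=O)c1ccccc1` with 5690 nM.

The change hydrogen in place of benzoyl on a nitrogen on an aromatic ring in a ring gave a 9.6-fold higher number from compound 2 to compound 1 (0.98 log units; beyond the scatter). The two cores differ by hydroxy in place of trifluoromethyl on an aromatic carbon, and that difference gave a 1.0-fold higher number from compound 2 to compound 3 (0.01 log units; within the scatter), so compound 2 and compound 3 show no separable difference in this assay.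

Compound 4 `O=C(Nc1ccccc1O)C1CCc2ccccc2N1` carries the same change, (hydrogen in place of benzoyl on a nitrogen on an aromatic ring in a ring), on the core of compound 3; the surroundings of the place read alike in both cases. For the measured compounds named here, it is expected to give an 8.8-fold higher number from compound 3 to compound 4 (0.94 log units; beyond the scatter), about as large as the earlier step, because a 9.6-fold higher number from compound 2 to compound 1 (0.98 log units; beyond the scatter) is the only guide here and the two cores behaved alike in compound 2 and compound 3. Compound 4 is therefore estimated at 50000 nM, expected to lie between 15000 nM and 150000 nM.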

Compound 4, concentration for 50% growth inhibition: 4310 nM
Compound 4: the middle estimate sits 12-fold (1.06 log units) above what was measured, and the stated range ends above it.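

In this assay, hydrogen in place of benzoyl on the core of compound 3 gave a 1.3-fold lower number from compound 3 to compound 4 (0.12 log units; within the scatter), so the step seen on the trifluoromethyl core did not carry over: the same change on two cores in this assay, a 9.6-fold higher number (0.98 log units; beyond the scatter) from compound 2 to compound 1 and a 1.3-fold lower number (0.12 log units; within the scatter) from compound 3 to compound 4, 13-fold (1.10 log units) apart, beyond the scatter of two such steps. Read the other way, hydroxy in place of trifluoromethyl, which made no separable difference with benzoyl present, gave a 12-fold lower number from compound 1 to compound 4 (1.09 log units; beyond the scatter) with hydrogen on the nitrogen: the same change on two cores in this assay, a 1.0-fold higher number (0.01 log units; within the scatter) from compound 2 to compound 3 and a 12-fold lower number (1.09 log units; beyond the scatter) from compound 1 to compound 4, 13-fold (1.10 log units) apart, beyond the scatter of two such steps. The two changes therefore depend on each other in these four compounds, so a step measured on one core could not be transferred to the other, but this rests on a single set of four compounds and does not show why.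

The compounds shown leave open whether this dependence holds with an acetyl or methyl group on the nitrogen. They also leave open what a methoxy group or a chlorine would do in place of the hydroxy.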